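Swapping phenyl for butyl on compound 2

This account rests on a few compounds, and the source may have more. Where it says the series, first, only, none or still open, it means among the compounds named here.

Compound 1 `O=C1OC(O)C(c2cccc(-c3csc4ccccc34)c2)=C1Br`: "not determined" (no result reported)
Compound 2 `O=C1OC(O)C(c2ccc(-c3ccc(-c4ccccc4)cc3)cc2)=C1Br`: 3610 nM

Within the data shown here, the only number so far comes from a functional assay on RAW264.7 cells (Mus musculus) for inhibition, read by immunoassay, with a stated time of 20 h (on this read-out higher numbers stand for weaker inhibition and lower numbers for stronger inhibition), where compound 2 gives 3610 nM. Among the measured compounds shown here, with no second value, there is nothing yet to rank compound 2 against, and no measured step shows how a change to this molecule plays out.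

Compound 3 `CCCCc1ccc(-c2ccc(C3=C(Br)C(=O)OC3O)cc2)cc1` keeps the shared core of compound 2 and alters one group: butyl in place of phenyl on an aromatic carbon. Put simply, it has butyl in place of phenyl on an aromatic carbon. For the measured compounds named here, with no measured step as a guide, this is a judgement call, and no clear direction is expected in this assay, only a shift within the usual scatter of repeat measurements. The expected change a 1.2-fold lower number from compound 2 to compound 3 (0.08 log units; within the scatter) is therefore small. Compound 3 is estimated at 3000 nM, with an expected range of 1200 nM to 8000 nM.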

Compound 3, half-maximal inhibitory concentration: 2240 nM
Compound 3: the middle estimate sits 1.3-fold (0.13 log units) above what was measured; measured number inside the range.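

In this assay, putting butyl in place of phenyl on an aromatic carbon gives a 1.6-fold lower number from compound 2 to compound 3 (0.21 log units; within the scatter), so the two groups cannot be told apart at this place, para to a large group. This first measured step shows that, in this one pair, an open butyl chain with no ring reads the same as a six-membered aromatic ring of carbon only, within the usual scatter of repeat measurements. Nothing on hand explains why these two groups read alike.

Only phenyl and butyl are shown at this place, so it remains open how an amine, a carboxylic acid or a longer chain such as octyl would read there. A single pair also cannot show whether any change at this position can move the number beyond the scatter, in either direction.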